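Antiproliferative series: third methoxy on the aryl of compound 2

This account rests on a few compounds, and the source may have more. Where it says the series, first, only, none or still open, it means among the compounds named here.

Two members of the series have been measured in a functional assay on IGROV-1 cells (Homo sapiens) for antiproliferative activity, with a stated time of 48 h; on this read-out lower numbers stand for stronger inhibition of growth and higher numbers for weaker inhibition of growth. Compound 1 `Cc1cc(O)c(C2=NN(c3ccc(S(N)(=O)=O)cc3)C(c3ccccc3O)C2)cc1Cl` gives 1630 nM in this assay. Compound 2 `COc1ccc(C2CC(c3cc(Cl)c(C)cc3O)=NN2c2ccc(S(N)(=O)=O)cc2)cc1OC` gives 2340 nM, the highest of the two numbers, with compound 1 nearest; the step of a 1.4-fold higher number from compound 1 to compound 2 (0.16 log units; within the scatter) lies within the scatter, so the two compounds stand together rather than in order.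

Compound 3 `COc1ccc(C2CC(c3cc(Cl)c(C)cc3O)=NN2c2ccc(S(N)(=O)=O)cc2)c(OC)c1OC` differs from compound 2 by methoxy in place of hydrogen on an aromatic carbon. Among the compounds with values here, the only measured step concerns the same aryl group on the saturated ring carbon, where a larger exchange of the whole group gave a 1.4-fold higher number from compound 1 to compound 2 (0.16 log units; within the scatter). Within the data shown here, no step for adding a single methoxy has been measured. For compound 3 no step beyond the scatter is therefore expected in this assay, the expected step being a 1.1-fold higher number from compound 2 to compound 3 (0.03 log units; within the scatter). Compound 3 is estimated to give 2500 nM, with an expected range from 1000 nM to 6500 nM.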

Compound 3, concentration for 50% growth inhibition: 2230 nM
Beside the measured number, compound 3's estimate is 1.1-fold (0.05 log units) above it; the measured number falls inside the stated range.
By their numbers in this assay, from the lowest: compounds 1, 3 and 2 (each within the scatter of the next).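

In this assay, methoxy in place of hydrogen on an aromatic carbon, ortho to a large group and ortho to a methoxy group, gives a 1.0-fold lower number from compound 2 to compound 3 (0.02 log units; within the scatter) as the first single-group step read on this aryl, so the change from 3,4-dimethoxyphenyl to 2,3,4-trimethoxyphenyl shifts the number by no more than the scatter. Set against the 2-hydroxyphenyl of compound 1, the 2,3,4-trimethoxyphenyl group gives a 1.4-fold higher number from compound 1 to compound 3 (0.14 log units; within the scatter) and so all three aryl groups shown on the saturated ring carbon stand together. No measurement at hand speaks to the reason for this flat result.

The aryl groups shown carry only hydroxy and methoxy, so it remains open whether an amine, a carboxylic acid or a longer alkoxy chain on this aryl would move the number beyond the scatter. Also open, as far as these compounds go, is whether the same added methoxy would give a similar step on the 2-hydroxyphenyl group of compound 1.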